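The source may hold more compounds than are shown below. What is called first, only, known or untested is meant among the compounds shown, and "the series" means these compounds.

Four compounds here share one core and differ in the group on a carbonyl carbon. In a functional assay on MT4 cells (Homo sapiens) for cytotoxicity (on this read-out higher numbers stand for lower toxicity in this test and lower numbers for higher toxicity in this test), compound 1 (`COc1ccc(C(=O)CSc2nc(O)c(C)c(Cc3cccc4ccccc34)n2)cc1`), which carries 4-methoxyphenyl, gives > 290000 nM as its result, and this is a limit, not a number. Compound 3 (`Cc1c(O)nc(SCC(=O)c2ccc(F)cc2)nc1Cc1cccc2ccccc12`), which carries 4-fluorophenyl, gives >= 275000 nM as its result, and this too is a limit, not a number. Compound 2 (`CC(=O)CSc1nc(O)c(C)c(Cc2cccc3ccccc23)n1`), which carries methyl, gives a true number of 85000 nM in the same test.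

Comparing the two limits yields a step that the two limits leave unreadable from compound 1 to compound 3 and so tells nothing. The readable steps are an at least 3.4-fold lower number from compound 1 to compound 2 (0.53 log units; beyond the scatter) and an at least 3.2-fold higher number from compound 2 to compound 3 (0.50 log units; beyond the scatter) and both lie beyond the scatter.

Compound 4 (`COC(=O)CSc1nc(O)c(C)c(Cc2cccc3ccccc23)n1`) has methoxy in place of 4-fluorophenyl on a carbonyl carbon. Like compound 2 at 85000 nM it has no ring on that carbonyl, so compound 2 is the closest guide, and an at least 3.2-fold higher number from compound 2 to compound 3 (0.50 log units; beyond the scatter) is the measured step that resembles this change, read in reverse. A move toward a lower number, meaning higher toxicity, is therefore expected, and the expected size is an at least 2.5-fold lower number from compound 3 to compound 4 (0.39 log units; beyond the scatter) in this assay. Compound 4 is estimated at 110000 nM, with an expected range from 45000 nM to 270000 nM in this test.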

Compound 4, half-maximal cytotoxic concentration: >= 296000 nM
Compound 4 was reported as a limit (the forecaster's own chance of this, stated with the estimate: 20%); middle value at least 2.6-fold (0.42 log units) from the limit.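

In this assay compound 4 gives >= 296000 nM, a limit and not a number, even though the methoxy it carries on the carbonyl carbon brings no ring. A ring at this position is therefore not required for a reading that high, and the lack of a ring does not by itself go with higher toxicity in this test. Methyl and methoxy, both without a ring, also read differently here, with an at least 3.4-fold higher number from compound 2 to compound 4 (0.54 log units; beyond the scatter), which leaves compound 2 as the only one of the four with a true number.

As far as these compounds go, the steps joining compound 4 to compound 1 and compound 3 link limit to limit and cannot be read, so the true values of these three compounds remain unknown and they cannot be placed in any order. Also open, from the compounds shown here alone, is whether a carboxylic acid, an amide built from an amine, or a longer chain such as ethyl on this carbonyl carbon would read like methyl in compound 2 or like methoxy in compound 4.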